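Compound 4: pyridine on a methyl link

The source may report more compounds than this note shows. Statements on the series, on what has been measured and on what is new or still open speak of the compounds shown alone.

Measured in a functional assay on Jurkat cells (Homo sapiens) for inhibition, read by CCK-8 assay, with a stated time of 48 h; a lower number here means a stronger inhibitor of growth, a higher number a weaker inhibitor of growth:
- compound 1 `Cc1ccccc1Nc1nc(Nc2ccccc2)ncc1Cl`: > 100000 nM (a limit, not a number)
- compound 2 `Cc1ccccc1Nc1nc(NCc2ccccc2)ncc1Cl`: > 100000 nM (a limit, not a number)
- compound 3 `Cc1ccccc1Nc1nc(Nc2ccccn2)ncc1Cl`: 20100 nM

Among the measured compounds shown here, compound 3, at 20100 nM, is the only compound here with a real number. The other two rest at the limit of > 100000 nM in this assay, at which 2 of the 3 values shown sit.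

Compound 4 `Cc1ccccc1Nc1nc(NCc2ccncc2)ncc1Cl` carries (pyridin-4-yl)methyl in place of pyridin-2-yl on a nitrogen on an aromatic ring.

The nearest guide is an at least 4.9-fold lower number from compound 2 to compound 3 (0.69 log units; beyond the scatter), where pyridin-2-yl replaced benzyl. The other guide is an at least 4.9-fold lower number from compound 1 to compound 3 (0.69 log units; beyond the scatter), where it replaced phenyl. Compound 4 gives up that pyridin-2-yl, yet its (pyridin-4-yl)methyl still holds a ring nitrogen, so only part of the gain is expected to be lost.

The expected step in this assay is a 2.5-fold higher number from compound 3 to compound 4 (0.40 log units; beyond the scatter), towards weaker growth inhibition. Compound 4 is estimated at 50000 nM, within a range of 15000 nM to 100000 nM.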

Compound 4, concentration for 50% growth inhibition: > 100000 nM
Compound 4: no number, only a limit; the forecaster's own chance of this, stated with the estimate: 35%; at least 2.0-fold (0.30 log units) between middle value and limit.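

In this assay, a ring nitrogen alone does not keep the gain seen with pyridin-2-yl: (pyridin-4-yl)methyl in its place gives an at least 4.9-fold higher number from compound 3 to compound 4 (0.69 log units; beyond the scatter) even though a six-membered aromatic ring with one hetero atom remains. The steps from compound 1 and from compound 2 to compound 4 cannot be read, as both ends of each are limits. The value of compound 4 is also a limit and not a number: the limit of > 100000 nM in this assay, at which 3 of the 4 values shown sit.

Two things change at once here, so the methyl link and the place of the ring nitrogen cannot be told apart. Pyridin-4-yl or (pyridin-2-yl)methyl, each changing only one of them, would separate the two.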